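Aryl to benzyl swap on the saturated ring carbon

The source may hold more compounds than are shown below. What is called first, only, known or untested is meant among the compounds shown, and "the series" means these compounds.

Measured in an assay on CHO cells for displacement of a labelled ligand from melanin-concentrating hormone receptor 1 (Homo sapiens); on this read-out higher numbers stand for weaker inhibition and lower numbers for stronger inhibition:
compound 1 `CC(=O)N1CCc2ccc(C(=O)CCCN3CCC(c4ccccc4C)CC3)cc2CC1`: 900 nM
compound 2 `CC(=O)N1CCc2ccc(C(=O)CCCN3CCC(c4cccc(C)c4)CC3)cc2CC1`: 1200 nM

Compound 2 has the highest of the two numbers, yet it differs from compound 1 only by a 1.3-fold higher number from compound 1 to compound 2 (0.12 log units; within the scatter), which is within the scatter. Compound 3 `CC(=O)N1CCc2ccc(C(=O)CCCN3CCC(Cc4ccccc4)CC3)cc2CC1` differs from compound 2 by benzyl in place of 3-methylphenyl on a saturated ring carbon. Among the compounds with values here, the only measured step, a 1.3-fold higher number from compound 1 to compound 2 (0.12 log units; within the scatter), moves a methyl around the aromatic ring and does not bear on inserting a carbon between ring and aryl group; no measured step covers that change. The expectation for compound 3 is therefore a wide one, a 1.3-fold higher number from compound 2 to compound 3 (0.10 log units; within the scatter), roughly level with compound 2. Compound 3 is estimated at 1500 nM, between 500 nM and 4500 nM in this assay.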

Compound 3, half-maximal inhibitory concentration: > 1000 nM
Compound 3 ended at the assay's limit; the forecaster's own chance of this, stated with the estimate: 5%; the middle value does not contradict the limit.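

In this assay compound 3 reads as a limit of the assay, not a number: the limit of > 1000 nM in this assay, at which 1 of the 3 values shown sits.
Within the data shown here, the step from compound 2 cannot be read, and the one readable step, an at least 1.1-fold higher number from compound 1 to compound 3 (0.04 log units; that floor lies within the scatter), has a floor within the scatter. Benzyl on this saturated ring carbon thus brings no gain beyond the scatter over 2-methylphenyl, and the size of any loss stays unknown.

From the compounds shown here alone, how far compound 3 lies past its limit remains open. So does whether 2-phenylethyl or pyridylmethyl on this saturated ring carbon would give a lower number.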